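The source may report more compounds than this note shows. Statements on the series, on what has been measured and on what is new or still open speak of the compounds shown alone.

Of the compounds shown here, three built on one shared core have been tested in a functional assay on DLD-1 cells (Homo sapiens) for inhibition, read by MTT assay, with a stated time of 72 h; a lower number here means a stronger inhibitor, a higher number a weaker inhibitor. Compound 1 `COc1ccc(CNCc2c(OC)cc(Oc3cccc(Nc4ccccc4)c3)cc2OC)cc1` gives 1910 nM. Compound 2 `COc1cc(Oc2cccc(Nc3ccccc3)c2)cc(OC)c1CNCCNC(C)=O` gives 6010 nM in this assay. Compound 3 `COc1cc(Oc2cccc(Nc3ccccc3)c2)cc(OC)c1CN[C@H](C)c1ccccc1` gives 8570 nM in this assay, the highest of the three numbers; the step of a 1.4-fold higher number from compound 2 to compound 3 (0.15 log units; within the scatter) lies within the scatter, while the step of a 4.5-fold higher number from compound 1 to compound 3 (0.65 log units; beyond the scatter) lies beyond it.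

Compound 4 `COc1ccc(CCCNCc2c(OC)cc(Oc3cccc(Nc4ccccc4)c3)cc2OC)cc1` has not yet been measured. The change from compound 3 is 3-(4-methoxyphenyl)propyl in place of 1-phenylethyl on an amine nitrogen. Among the compounds with values here, two measured steps bear on it. The step of a 4.5-fold higher number from compound 1 to compound 3 (0.65 log units; beyond the scatter) replaced a 4-methoxybenzyl group, which carries the same methoxy-bearing ring that now returns, with the 1-phenylethyl group that now leaves. The step of a 1.4-fold higher number from compound 2 to compound 3 (0.15 log units; within the scatter) shows that exchanging one chain-bearing group for 1-phenylethyl changed little. Within the data shown here, no measured compound carries a 3-(4-methoxyphenyl)propyl group, so the effect of the longer chain is unknown.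

Because the step of a 4.5-fold higher number from compound 1 to compound 3 (0.65 log units; beyond the scatter) raised the number when the methoxy-bearing ring was removed, a lower number than compound 3 is expected for compound 4, though probably not as low as compound 1. The step of a 2.7-fold lower number from compound 3 to compound 4 (0.43 log units; beyond the scatter) is therefore expected. Compound 4 is estimated to give 3200 nM, within a range from 1200 nM to 8500 nM.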

Compound 4, half-maximal inhibitory concentration: 2540 nM
Compound 4: middle estimate off by 1.3-fold (0.10 log units), on the high side; low and high end bracket the measured number.
By their numbers in this assay, from the lowest: compounds 1 and 4 (each within the scatter of the next); then compounds 2 and 3 (each within the scatter of the next).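

In this assay, putting 3-(4-methoxyphenyl)propyl in place of 1-phenylethyl on the amine nitrogen gives a 3.4-fold lower number from compound 3 to compound 4 (0.53 log units; beyond the scatter), and the comparison with the acetamido compound gives a 2.4-fold lower number from compound 2 to compound 4 (0.37 log units; beyond the scatter), so this position responds to the new group by more than the scatter. The step of a 1.3-fold higher number from compound 1 to compound 4 (0.12 log units; within the scatter) lies within the scatter, which shows something new: the 4-methoxyphenyl ring can sit at the end of a longer chain than in the 4-methoxybenzyl group with no measurable difference in this assay, and the two compounds carrying that ring both stand apart from compounds 2 and 3. Nothing measured here explains why these numbers fall as they do.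

As far as these compounds go, it remains open whether the methoxy group or the chain matters more, since compound 3 differs from compound 4 in the methoxy group, the chain length and the branching all at once, and a plain 3-phenylpropyl group or a 1-(4-methoxyphenyl)ethyl group would begin to separate them. Also open, from the compounds shown here alone, is how far the chain can grow, as with a 4-(4-methoxyphenyl)butyl group, and whether a carboxylic acid or an amine in place of the methoxy group would be tolerated.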